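Methyl in Place of Methoxy on the Aromatic Ring

The source may report more compounds than this note shows. Statements on the series, on what has been measured and on what is new or still open speak of the compounds shown alone.

Compound 1 `N=C(NCc1ccccc1)[C@@H]1CCC(=O)N1Cc1ccc(F)cc1`: 31.4%
Compound 2 `COc1ccc(CN2C(=O)CC[C@H]2C(=N)NCc2ccccc2)cc1`: 17.9%

Two compounds share one core and differ only at one aromatic carbon. In a functional assay on SH-SY5Y cells (Homo sapiens) for cytotoxicity, read by MTT assay, with stated times of 8 h, 30 min and 12 h, tested at 5 uM (a lower number here means a weaker effect, a higher number a stronger effect of the compound at the concentration tested), compound 1 gives 31.4% and compound 2 gives 17.9%. Compound 2 thus stands lowest of the two numbers, with the step of a number 13.5 percentage points lower from compound 1 to compound 2 (beyond the scatter). Compound 3 `Cc1ccc(CN2C(=O)CC[C@H]2C(=N)NCc2ccccc2)cc1` is unmeasured; it differs from compound 2 in that (methyl in place of methoxy on an aromatic carbon). Among the compounds with values here, the only step available is the one at this same aromatic carbon, fluoro to methoxy, which was modest and beyond the scatter. Neither measured compound carries a methyl there, so that step gives only a rough guide to size. For compound 3 a small step is expected in this assay, a number 4.1 percentage points higher from compound 2 to compound 3 (within the scatter), not clearly beyond the scatter. Compound 3 is therefore estimated at 22%, within the range 10% to 36%.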

Compound 3, a percentage reported as activity, at one concentration (the size of the read-out at that concentration, not a potency): 24.8%
Compound 3: middle estimate off by 2.8 percentage points, on the low side; measured number inside the range.
By their numbers in this assay, from the lowest: compounds 2, 3 and 1 (each within the scatter of the next, the first and the last beyond it).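

In this assay, replacing methoxy with methyl gives a number 6.9 percentage points higher from compound 2 to compound 3 (within the scatter) and replacing fluoro with methyl gives a number 6.6 percentage points lower from compound 1 to compound 3 (within the scatter) at this same aromatic carbon. Methyl therefore cannot be separated from either of the other two groups, even though fluoro and methoxy themselves differ, with a number 13.5 percentage points lower from compound 1 to compound 2 (beyond the scatter) as the only step here beyond the scatter. No measurement given here accounts for these numbers.

What the three compounds leave open is whether any other group on this carbon, such as an amine, a carboxylic acid or a longer chain like propyl, would move the number beyond the scatter from compound 3. They also leave open whether methyl in place of methoxy would give a similar step on another carbon of this ring.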